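The source may hold more compounds than are shown below. What is called first, only, known or untested is meant among the compounds shown, and "the series" means these compounds.

Compounds measured in a functional assay on LNCaP C4-2B cells (Homo sapiens) for antiproliferative activity, read by luminescence, with a stated time of 96 h; a higher number here means a weaker inhibitor, a lower number a stronger inhibitor:

- Compound 1 `CC1(C)Oc2cc(NS(=O)(=O)C3CCCCC3)ccc2NC1=O`: 7040 nM
- Compound 2 `CC1(C)Oc2cc(NS(=O)(=O)c3ccccc3)ccc2NC1=O`: 13300 nM
- Compound 3 `COc1cc2c(cc1NS(=O)(=O)c1cc(Br)ccc1OC)OC(C)(C)C(=O)N2`: 3230 nM

Of these three, compound 3 has the lowest number, so it is the strongest inhibitor here, and its gaps to compound 1 and compound 2 both lie beyond the usual scatter. Compound 4 `COc1ccc(Br)cc1S(=O)(=O)Nc1cc2c(cc1O)NC(=O)C(C)(C)O2` differs from compound 3 in one place, with hydrogen in place of methyl on an oxygen on an aromatic ring, turning methoxy to hydroxy (hydrogen in place of methyl on an oxygen on an aromatic ring).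

Going by the values given here, only one measured step is available, a 1.9-fold higher number from compound 1 to compound 2 (0.28 log units; within the scatter). It puts phenyl in place of cyclohexyl on a sulfonyl sulfur, which is a different place and a different kind of change. Among the compounds with values here, it therefore offers only a loose sense of scale, and no measured compound shows what methoxy to hydroxy does. With so little guidance, no change beyond the scatter is expected in this assay, though a slightly higher number seems a little more likely than a lower one. The estimated step is a 1.2-fold higher number from compound 3 to compound 4 (0.09 log units; within the scatter). For compound 4 the expected value is 4000 nM, with an estimated range of 1300 nM to 11000 nM.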

Compound 4, half-maximal inhibitory concentration: 7750 nM
Beside the measured number, compound 4's estimate is 1.9-fold (0.29 log units) below it; measured number inside the range.
By their numbers in this assay, from the lowest: compound 3; then compounds 1, 4 and 2 (each within the scatter of the next).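

In this assay, replacing methoxy with hydroxy on the aromatic ring gives a 2.4-fold higher number from compound 3 to compound 4 (0.38 log units; beyond the scatter), a modest loss of potency that lies beyond the scatter. Going by these compounds alone, this is the first measured sign that a change at this oxygen can shift activity, as the only earlier step concerned the group on the sulfonyl sulfur. Nothing available explains the loss, and no supporting measurement bears on this result.

As far as these compounds go, the pair alone cannot separate the effect of removing the methyl from that of gaining the hydroxy, so a longer chain such as ethoxy or a different group such as an amine at this place remains untested here. From the compounds shown here alone, whether the same swap would have a similar effect on a compound with a different group on the sulfonyl sulfur, such as cyclohexyl, also remains open.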